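The source may report more compounds than this note shows. Statements on the series, on what has been measured and on what is new or still open speak of the compounds shown alone.

Measured in an ADME assay on HepG2 cells (Homo sapiens) for cytotoxicity, read by luminescence, with a stated time of 72 h; on this read-out higher numbers stand for an effect only at larger amounts of compound and lower numbers for an effect already at smaller amounts:
- Compound 1 `CCOC(=O)c1c(-c2cccc(C)c2)[nH]c2cc(OC)ccc2c1=O`: > 21500 nM
- Compound 2 `CCOC(=O)c1c(-c2cccc(-c3ccccc3)c2)[nH]c2cc(OC)ccc2c1=O`: > 21500 nM
- Compound 3 `CCOC(=O)c1c(-c2cccc(Br)c2)[nH]c2cc(OC)ccc2c1=O`: > 21500 nM

Each of these entries is a limit and not a number. Compound 2 gives > 21500 nM, so it has no exact place on the scale. It shares that position with the other two compounds: the limit of > 21500 nM in this assay, at which 3 of the 3 values shown sit.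

Compound 4 `CCOC(=O)c1c(-c2cccc(-c3ccccc3)c2)[nH]c2cc(OC(C)C)ccc2c1=O` differs from compound 2 in one place, with isopropyl in place of methyl on an oxygen on an aromatic ring, which turns methoxy into isopropoxy: isopropyl in place of methyl on an oxygen on an aromatic ring.

Three measured steps could offer a guide: a step that the two limits leave unreadable from compound 1 to compound 2, a step that the two limits leave unreadable from compound 1 to compound 3 and a step that the two limits leave unreadable from compound 2 to compound 3. All three swap groups on an aromatic carbon, so none of them makes this change on the oxygen, and none has a size that can be read.

Compound 2 at > 21500 nM is therefore the only anchor for the expectation, and that entry is a limit. In this assay, no step beyond the usual scatter is expected in either direction, and the estimated change is a number no higher from compound 2 to compound 4 (the limit leaves the size open). A further limit is expected to be a more likely report than an exact number. For compound 4 the estimate is 21500 nM, with an expected range from 10000 nM to 45000 nM.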

Compound 4, half-maximal effective concentration: > 21500 nM
Compound 4 ended at the assay's limit; the forecaster's own chance of this, stated with the estimate: 75%; the middle value lies on the limit itself.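

Compound 2 and compound 4 both end as limits and not as exact numbers, so the change from methoxy to isopropoxy gives no step that can be read: the limit of > 21500 nM in this assay, at which 4 of the 4 values shown sit.

The compounds shown leave open at what amount any of the four would show an effect in this assay, and whether the change from methoxy to isopropoxy shifts that amount at all.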